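Working notes: compound 3 to compound 4

The source may hold more compounds than are shown below. What is called first, only, known or untested is meant among the compounds shown, and "the series" means these compounds.

Compound 3 `COc1ccc(C2Nc3ccccc3C(=O)N2c2ccccc2)cc1COc1ccc(NC(C)=O)cc1` stands second highest of the three numbers in a functional assay on HEK-EM293 cells for agonist activity at Thyrotropin receptor (Homo sapiens), read by ELISA and cAMP accumulation, with a stated time of 1 h; on this read-out higher numbers stand for larger maximal responses and lower numbers for smaller maximal responses: compound 3 gives 75.1%, with compound 2 `COc1ccc(C2Nc3cccc(F)c3C(=O)N2Cc2ccccc2)cc1COc1ccc(NC(C)=O)cc1` nearest and higher at 94.7% and compound 1 `COc1ccc(C2Nc3cccc(OC)c3C(=O)N2Cc2ccccc2)cc1COc1ccc(NC(C)=O)cc1` furthest and lower at 49.1%. Both gaps lie beyond the scatter. Going by the values given here, the only measured step, a number 45.6 percentage points higher from compound 1 to compound 2 (beyond the scatter), concerns a substituent on an aromatic carbon and does not bear on the change now followed. Compound 4 `COc1ccc(C2Nc3ccccc3C(=O)N2CCCN(C)C)cc1COc1ccc(NC(C)=O)cc1` differs from compound 3 by 3-(dimethylamino)propyl in place of phenyl on an amide-type nitrogen in a ring. Among the compounds with values here, no measured step touches this position, so no direction beyond the scatter can be argued from the data. The expected step is a number 5.1 percentage points lower from compound 3 to compound 4 (within the scatter), held close to compound 3 with a wide range. Compound 4 is thus estimated at 70%, within 35% to 100%.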

Compound 4, largest response reached (Emax), in percent of the reference or control that the assay uses: 10.1%
For compound 4 the middle estimate is 59.9 percentage points above the measured one; measured number outside the range, below it.
By their numbers in this assay, from the lowest: compound 4; then compound 1; then compound 3; then compound 2.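

In this assay, 3-(dimethylamino)propyl in place of phenyl on the amide-type nitrogen in a ring gives a number 65 percentage points lower from compound 3 to compound 4 (beyond the scatter), so the maximal response depends strongly on the group at this position. The change replaces a six-membered aromatic ring of carbon only with a chain that has no ring and carries a hydrogen-bond acceptor, and this single step cannot separate those differences. No available evidence accounts for the drop. Open, as far as these compounds go, is whether a plain propyl chain or a 3-phenylpropyl chain stays with compound 3 or falls with compound 4, which would separate losing the phenyl ring from adding the dimethylamino group.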